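Extending the Alkyl Chain on a Triazole Aminosugar Scaffold

The source may hold more compounds than are shown below. What is called first, only, known or untested is meant among the compounds shown, and "the series" means these compounds.

The shared core carries a triazole whose nitrogen bears a straight alkyl chain, and the study follows what happens as that chain grows. Compound 1 `CCCCCCCn1cc(COC[C@@H]2OC[C@H](N)[C@@H]2O)nn1` is the shortest member. In a functional assay on MCF7 cells (Homo sapiens) for antiproliferative activity, read by MTT assay, with a stated time of 48 h (a lower number here means a stronger inhibitor, a higher number a weaker inhibitor), compound 1 gives only a limit, > 128000 nM, which marks the edge of what the measurement can report (the limit of > 128000 nM in this assay, at which 1 of the 2 values shown sits). Compound 2 `CCCCCCCCCCn1cc(COC[C@@H]2OC[C@H](N)[C@@H]2O)nn1` differs from compound 1 by a propyl in place of hydrogen on a saturated chain carbon, seven bonds along the chain from an aromatic nitrogen; in this assay compound 2 gives 9640 nM. Among the measured compounds shown here, that step, an at least 13-fold lower number from compound 1 to compound 2 (1.12 log units; beyond the scatter), is the only measured step here.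

Compound 3 `CCCCCCCCCCCCCCn1cc(COC[C@@H]2OC[C@H](N)[C@@H]2O)nn1` is the next member, not yet measured. Against compound 1 it shows (heptyl in place of hydrogen on a saturated chain carbon, seven bonds along the chain from an aromatic nitrogen), a longer version of the same change that produced the large step from compound 1 to compound 2. For the measured compounds named here, the one measured step therefore points toward a further decrease in the number, though the single comparison gives no guidance on how far the trend continues. Compound 3 is expected to give about 3000 nM in this assay, estimated between 600 nM and 15000 nM. That corresponds to an expected step of an at least 42-fold lower number from compound 1 to compound 3 (1.63 log units; beyond the scatter).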

Compound 3, half-maximal inhibitory concentration: 1850 nM
The estimate for compound 3 lay 1.6-fold (0.21 log units) above the measured number; the measured number falls inside the stated range.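

The chain still responds at its outer reach: a butyl in place of hydrogen on a saturated chain carbon gives a 5.2-fold lower number from compound 2 to compound 3 (0.72 log units; beyond the scatter) in this assay. So the effect of lengthening did not end with compound 2, although this modest step follows a large one even with more carbon added, which hints that each added carbon may bring less, a reading that rests on three compounds alone. The full heptyl change gives an at least 69-fold lower number from compound 1 to compound 3 (1.84 log units; beyond the scatter), but compound 1 stands at a limit and not at a number, so this step and the earlier one from the same compound are bounds on their size: the limit of > 128000 nM in this assay, at which 1 of the 3 values shown sits.

What the compounds shown leave open is whether a longer chain than that of compound 3 would lower the number further, hold it level or raise it again, so the shape of the trend beyond compound 3 is unknown. They also leave open whether the chain's effect depends on its being purely hydrocarbon, as an amine or a carboxylic acid carried on the chain would test.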